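Replacing the aminoethyl amide with an ethylpyrrolidinylmethyl amide

A few compounds are considered here, and "the series" means these few. Any claim that something is new, unique, unknown or untested is made for them only; others in the source may bear on it.

Compound 1 `CC(C)N1CC[C@H](NC(=O)c2cc(-c3ccc(NS(=O)(=O)c4cccc(Cl)c4Cl)cc3)nc3[nH]ncc23)C1`: in an assay for inhibition of serine/threonine-protein kinase Sgk1 (Homo sapiens), with stated times of 30 min and 60 min, in the presence of a further agent that is not named here (on this read-out higher numbers stand for weaker inhibition and lower numbers for stronger inhibition), compound 1 gives 4 nM.
Compound 2 `CCNC(=O)c1cc(-c2ccc(NS(=O)(=O)c3cccc(Cl)c3Cl)cc2)nc2[nH]ncc12`: in this assay compound 2 gives 6 nM.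
Compound 3 `NCCNC(=O)c1cc(-c2ccc(NS(=O)(=O)c3cccc(Cl)c3Cl)cc2)nc2[nH]ncc12`: in this assay compound 3 gives < 1 nM, which is a limit of the assay and not a number.

Compound 3 sits at the limit of < 1 nM in this assay, at which 1 of the 3 values shown sits, so only a limit is known for it. The two steps leading to it are both beyond the scatter: an at least 4.0-fold lower number from compound 1 to compound 3 (0.60 log units; beyond the scatter) and an at least 6.0-fold lower number from compound 2 to compound 3 (0.77 log units; beyond the scatter). The step between the other two, a 1.5-fold higher number from compound 1 to compound 2 (0.18 log units; within the scatter), is within the scatter.

Compound 4 `CCN1CCC(CNC(=O)c2cc(-c3ccc(NS(=O)(=O)c4cccc(Cl)c4Cl)cc3)nc3[nH]ncc23)C1` differs from compound 3 by 1-ethylpyrrolidin-3-yl in place of aminomethyl on a saturated chain carbon bound to an amide-type nitrogen. The 2-aminoethyl of compound 3 thus becomes (1-ethylpyrrolidin-3-yl)methyl, a side chain resembling the 1-isopropylpyrrolidin-3-yl of compound 1, and the primary amine that set compound 3 apart from compounds 1 and 2 is gone. Compound 4 is therefore expected to fall back toward compound 1 and compound 2, a step of an at least 3.0-fold higher number from compound 3 to compound 4 (0.47 log units; beyond the scatter). In this assay compound 4 is estimated at 3 nM, within a range from 1 nM to 10 nM.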

Compound 4, half-maximal inhibitory concentration: < 1 nM
Compound 4: no number, only a limit; the forecaster's own chance of this, stated with the estimate: 20%; at least 3.0-fold (0.47 log units) between middle value and limit.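

In this assay compound 4 gives < 1 nM, which is a limit of the assay and not a number. The step from compound 3 to compound 4 cannot be read, so the two cannot be ordered, and the loss of the primary amine of the 2-aminoethyl group does not lift compound 4 off the limit shared by both: the limit of < 1 nM in this assay, at which 2 of the 4 values shown sit. The (1-ethylpyrrolidin-3-yl)methyl group also stands apart from the two other amide side chains without a primary amine, with an at least 6.0-fold lower number from compound 2 to compound 4 (0.77 log units; beyond the scatter) and an at least 4.0-fold lower number from compound 1 to compound 4 (0.60 log units; beyond the scatter).

The compounds shown leave open which part of the change from 1-isopropylpyrrolidin-3-yl to (1-ethylpyrrolidin-3-yl)methyl carries that last step. They also leave open how a piperidine or a carboxylic acid would read on the same saturated chain carbon bound to the amide-type nitrogen.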